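A larger group on compound 2

This account rests on a few compounds, and the source may have more. Where it says the series, first, only, none or still open, it means among the compounds named here.

For the measured compounds named here, in an ADME assay on microsomes from liver (Mus musculus) for metabolic stability, using NADPH, with a stated time of 10 min (a higher number here means that more of the compound is left, a lower number that less of the compound is left), compound 2 `CN(C)[C@H]1CCN(c2cccc3c2C[C@H](CN(C)[C@H]2CCCc4cccnc42)NC3)C1` gives 18.5% as the lowest of the three numbers so far. Compound 1 `CN(C[C@H]1Cc2c(cccc2N2CCC(N)CC2)CN1)[C@H]1CCCc2cccnc21` gives 70.3% and compound 3 `CN1CCN(Nc2cccc3c2C[C@@H](CN(C)[C@H]2CCCc4cccnc42)NC3)CC1` gives 85.8% and both stand far higher, beyond the scatter. Compound 4 `CN1CC[C@H]2CN(c3cccc4c3C[C@H](CN(C)[C@H]3CCCc5cccnc53)NC4)C[C@H]21` differs from compound 2 in a single group (a group of 9 heavy atoms (7 carbon, 2 nitrogen; 2 five-membered non-aromatic rings with 1 hetero atom each) in place of a group of 8 heavy atoms (6 carbon, 2 nitrogen; one five-membered non-aromatic ring with 1 hetero atom), on an aromatic carbon). Going by the values given here, one measured step bears on this, also a swap on an aromatic carbon, and it is large (a number 51.8 percentage points lower from compound 1 to compound 2 (beyond the scatter)). That swap moved the number far, yet it tells nothing about this new group. Compound 2 at 18.5% has little room left to fall. A moderate rise is therefore expected (a number 16.5 percentage points higher from compound 2 to compound 4 (beyond the scatter)). Compound 4 is estimated at 35% (expected range 12% to 70%).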

Compound 4, percent of the compound remaining: 24%
Beside the measured number, compound 4's estimate is 11 percentage points above it; measured number inside the range.
By their numbers in this assay, from the lowest: compounds 2 and 4 (each within the scatter of the next); then compound 1; then compound 3.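

In this assay, the group with 2 five-membered non-aromatic rings, in place of 3-(dimethylamino)pyrrolidin-1-yl on the aromatic carbon, gives a number 5.5 percentage points higher from compound 2 to compound 4 (within the scatter), so the two groups cannot be told apart here. In place of 4-aminopiperidin-1-yl, the same group gives a number 46.3 percentage points lower from compound 1 to compound 4 (beyond the scatter), so among compounds 1, 2 and 4 only the piperidine-bearing compound 1 stands high. Nothing measured here gives a reason for this. On these data alone, it remains open whether the six-membered ring or the free amino group of compound 1 goes with the higher number. The groups 3-aminopyrrolidin-1-yl and 4-(dimethylamino)piperidin-1-yl at this place would separate the two.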